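Tail amine swap on the quinoline ether series

The source may hold more compounds than are shown below. What is called first, only, known or untested is meant among the compounds shown, and "the series" means these compounds.

Measured so far:
- compound 1 `COc1cc2c(Oc3c(F)cc(NC(=O)NN4C(=O)CSC4c4c(F)cccc4F)cc3F)ccnc2cc1OCCCN1CCCC1`: 8350 nM
- compound 2 `COc1cc2c(Oc3c(F)cc(NC(=O)NN4C(=O)C(C)SC4c4c(F)cccc4F)cc3F)ccnc2cc1OCCCN1CCCC1`: "not determined" (no result reported)
- compound 3 `COc1cc2c(Oc3c(F)cc(NC(=O)NN4C(=O)C(C)(C)SC4c4c(F)cccc4F)cc3F)ccnc2cc1OCCCN1CCCC1`: "not determined" (no result reported)

For the measured compounds named here, compound 1 carries the only number in the set. In a functional assay on MDA-MB-231 cells (Homo sapiens) for antiproliferative activity, read by MTT assay, with a stated time of 72 h (on this read-out lower numbers stand for stronger inhibition and higher numbers for weaker inhibition), compound 1 gives 8350 nM, a weak result on this read-out. Going by the values given here, compound 2 and compound 3 vary the thiazolidinone ring of the shared core; in this assay compound 2 gives "not determined" (no result reported) and compound 3 gives "not determined" (no result reported), so no step between measured compounds can be stated and nothing can be said about how the core change bears on potency.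

Compound 4 `CCN(CC)CCCOc1cc2nccc(Oc3c(F)cc(NC(=O)NN4C(=O)CSC4c4c(F)cccc4F)cc3F)c2cc1OC` differs from compound 1 only at the far end of the chain: diethylamino in place of pyrrolidin-1-yl on a saturated chain carbon, three bonds along the chain from an oxygen on an aromatic ring. The change is remote from the urea and the thiazolidinone, and the two groups match in heavy-atom count and acceptor count. Among the compounds with values here, with no measured pair to anchor a direction, no step beyond the scatter is expected; the step from compound 1 to compound 4 is estimated as a 1.1-fold higher number from compound 1 to compound 4 (0.03 log units; within the scatter), essentially flat. Compound 4 is therefore expected to give about 9000 nM in this assay, with a range from 4000 nM to 20000 nM.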

Compound 4, half-maximal inhibitory concentration: 3790 nM
Beside the measured number, compound 4's estimate is 2.4-fold (0.38 log units) above it; the whole stated range lies above it.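

In this assay, for the compounds shown here, the swap of pyrrolidin-1-yl for diethylamino gives a 2.2-fold lower number from compound 1 to compound 4 (0.34 log units; beyond the scatter) and so provides the first readable step. The far end of the chain therefore registers a modest change in potency, even though both groups have the same heavy-atom and acceptor counts and differ in that diethylamino has no ring. No measured evidence available here accounts for this step.

On these data alone, one swap gives no trend across tail amines, so it remains open how morpholine, 4-methylpiperazine or dimethylamino would read at the end of the same chain, or how a longer chain carrying diethylamino would behave. As far as these compounds go, it also remains open whether the step would carry over to the cores of compound 2 and compound 3.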